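Compound 3 to compound 4: notes on tolerance

The compounds below may be only part of what the source reports. "The series", "measured", "known", "first", "only" and "open" are said of these compounds alone.

- compound 1 `Fc1cccc(F)c1Cn1c(-c2c(F)cccc2F)nc2cnccc21`: limit > 100000 nM
- compound 2 `Fc1cccc(F)c1Cn1cccc2nc(-c3c(F)cccc3F)nc1-2`: limit > 100000 nM
- compound 3 `Fc1cccc(F)c1Cn1ccc2nc(-c3ccccc3)nc-2c1`: limit > 100000 nM

All three entries are limits of an ADME assay on MDBK cells (Bos taurus) for cytotoxicity (a lower number here means that less compound is tolerated, a higher number that more compound is tolerated), and not numbers. Compound 3 stands at the limit > 100000 nM, so no number places it within the series.

Compound 4 `COc1ccccc1Cn1ccc2nc(-c3ccccc3)nc-2c1` carries 2-methoxyphenyl in place of 2,6-difluorophenyl on a saturated chain carbon bound to an aromatic nitrogen. Among the compounds with values here, the measured compounds offer no single-place step, so the size of this change cannot be read directly from them.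

The expectation rests on compound 3 with its limit > 100000 nM, and no step beyond the scatter is expected in this assay because the limit of > 100000 nM in this assay, at which 3 of the 3 values shown sit, applies across the series. The expected size is a number no higher from compound 3 to compound 4 (the limit leaves the size open) in this estimate. For compound 4 the estimated value is 100000 nM, with an expected range from 40000 nM to 200000 nM, and a report as a limit is likely.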

Compound 4, half-maximal cytotoxic concentration: > 100000 nM
Compound 4: a limit, no number (the forecaster's own chance of this, stated with the estimate: 75%); the middle value sits exactly at the limit.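

No step can be read from compound 3 to compound 4 in this assay, as both entries are limits and not numbers: the limit of > 100000 nM in this assay, at which 4 of the 4 values shown sit.

The compounds shown leave open whether 2-methoxyphenyl in place of 2,6-difluorophenyl on a saturated chain carbon bound to an aromatic nitrogen alters tolerance at all.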